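The source may hold more compounds than are shown below. What is called first, only, known or untested is meant among the compounds shown, and "the series" means these compounds.

Compounds measured in a functional assay on MCF7 cells (Homo sapiens) for cytotoxicity, read by MTT assay, with a stated time of 72 h; on this read-out lower numbers stand for stronger inhibition and higher numbers for weaker inhibition:
- Compound 1 `FC(F)(F)c1ccc(CSc2nc(Nc3ccccc3)c3ccccc3n2)cc1`: 44000 nM
- Compound 2 `FC(F)(F)c1ccc(CSc2nc(Nc3cccc(Cl)c3)c3ccccc3n2)cc1`: 25100 nM
- Compound 3 `Cc1ccc(Nc2nc(SCc3ccc(C(F)(F)F)cc3)nc3ccccc23)cc1`: the assay reports only a limit, > 50000 nM

Compound 1 holds the higher of the two numbers given; its nearest neighbour is compound 2, and the step of a 1.8-fold lower number from compound 1 to compound 2 (0.24 log units; within the scatter) falls within the scatter. For compound 3 only the limit of > 50000 nM in this assay, at which 1 of the 3 values shown sits, is known.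

Compound 4 `COc1cc(Nc2nc(SCc3ccc(C(F)(F)F)cc3)nc3ccccc23)cc(OC)c1` differs from compound 1 at one place: 3,5-dimethoxyphenyl in place of phenyl on a nitrogen on an aromatic ring. For the measured compounds named here, the steps that bear on this change are those altering the same ring on the nitrogen: a 1.8-fold lower number from compound 1 to compound 2 (0.24 log units; within the scatter), an at least 1.1-fold higher number from compound 1 to compound 3 (0.05 log units; that floor lies within the scatter) and an at least 1.9-fold higher number from compound 2 to compound 3 (0.29 log units; that floor lies within the scatter), none of which reaches beyond the scatter. Going by the values given here, no measured step therefore supports a move in either direction larger than the scatter in this assay, and the series sits close to the limit throughout.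

Compound 4 is accordingly expected to show a step of about a 1.1-fold lower number from compound 1 to compound 4 (0.04 log units; within the scatter), which amounts to no change beyond the scatter. The estimate for compound 4 is 40000 nM, expected to lie between 15000 nM and 100000 nM, with a fair chance that only a limit is reported.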

Compound 4, half-maximal inhibitory concentration: 6990 nM
Compound 4: the middle estimate sits 5.7-fold (0.76 log units) above what was measured; the whole stated range lies above it.
By their numbers in this assay, from the lowest: compound 4; then compounds 2 and 1 (each within the scatter of the next). At a limit, above all of these: compound 3.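

On the ring on the nitrogen, the 3,5-dimethoxyphenyl group is the only change shown that moves the number in this assay beyond the scatter relative to the unsubstituted phenyl: a 6.3-fold lower number from compound 1 to compound 4 (0.80 log units; beyond the scatter). For the compounds shown here, the same group also stands clear of the 3-chlorophenyl group, with a 3.6-fold lower number from compound 2 to compound 4 (0.56 log units; beyond the scatter), so substitution on this ring can matter even though the earlier steps did not show it. Against the 4-methylphenyl group the step is only a floor, an at least 7.1-fold lower number from compound 3 to compound 4 (0.85 log units; beyond the scatter), since that comparison rests on a limit: the limit of > 50000 nM in this assay, at which 1 of the 4 values shown sits.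

From the compounds shown here alone, whether a single methoxy group would give a similar step remains open, as does what a hydroxy group or an amine at the same place would do. The compounds shown also leave open why the number falls.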